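Adding a Chloro Group to the Phenyl Ring of Compound 1

A few compounds are considered here, and "the series" means these few. Any claim that something is new, unique, unknown or untested is made for them only; others in the source may bear on it.

Among the compounds with values here, in a functional assay on T98G cells (Homo sapiens) for inhibition, read by MTT assay, with a stated time of 72 h (a higher number here means a weaker inhibitor, a lower number a stronger inhibitor), compound 1 (`CC1(C)CC(NC(=O)Nc2ccccc2)c2cc(Cl)ccc2O1`) gives 34000 nM and sits in the middle of the three compounds measured so far. Compound 3 (`CC(C)NC(=S)NC1CC(C)(C)Oc2ccc(Cl)cc21`) is the weakest at 91000 nM in this small set. Compound 2 (`CC1(C)CC(NC(=S)Nc2cccc([N+](=O)[O-])c2)c2cc(Br)ccc2O1`) is the strongest at 4000 nM in the same set, and both gaps to compound 1 lie beyond the scatter.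

Compound 4 (`CC1(C)CC(NC(=O)Nc2ccc(Cl)cc2)c2cc(Cl)ccc2O1`) keeps compound 1 intact except at one spot (chloro in place of hydrogen on an aromatic carbon), where phenyl becomes 4-chlorophenyl, with chloro in place of hydrogen on an aromatic carbon. Within the data shown here, no measured pair isolates this change. Among the measured compounds shown here, the only hint is compound 2 at 4000 nM with a substituent on the matching aromatic ring, but it also differs from compound 1 elsewhere, so the hint is weak. The expected change is a 2.4-fold lower number from compound 1 to compound 4 (0.39 log units; beyond the scatter) as a modest move toward a lower number, only slightly beyond the scatter. Compound 4 is estimated at 14000 nM in this assay, with an expected range from 5000 nM to 40000 nM around that figure.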

Compound 4, half-maximal inhibitory concentration: 33000 nM
Compound 4: the middle estimate sits 2.4-fold (0.37 log units) below what was measured; measured number inside the range.
By their numbers in this assay, from the lowest: compound 2; then compounds 4 and 1 (each within the scatter of the next); then compound 3.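

Within the data shown here, this pair is the first to isolate one change, chloro in place of hydrogen on an aromatic carbon, turning phenyl into 4-chlorophenyl. In this assay this single swap gives a 1.0-fold lower number from compound 1 to compound 4 (0.01 log units; within the scatter) and so leaves the number unchanged within the scatter. At this spot, para to a large group, adding chloro therefore does not separate the two compounds, and no other kind of measurement is available to help interpret this result.

From the compounds shown here alone, whether another group at the same spot, such as an amine, a carboxylic acid or a methoxy group, would move the number remains open. Going by these compounds, it is also open whether chloro placed elsewhere on this ring would behave in the same way.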